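Working notes on a dichloroacetamide biaryl series

The source may report more compounds than this note shows. Statements on the series, on what has been measured and on what is new or still open speak of the compounds shown alone.

Two members of the series have been measured in a functional assay on KB 3-1 cells (Homo sapiens) for cytotoxicity, read by MTT assay, with a stated time of 68 h; a higher number here means a weaker inhibitor, a lower number a stronger inhibitor. Compound 1 `CSc1cccc(-c2cc(NC(=O)C(Cl)Cl)cc(-c3cccc(SC)c3)c2)c1` gives > 30000 nM in this assay, which is a limit of the assay and not a number; compound 1 therefore sits at the limit of > 30000 nM in this assay, at which 1 of the 2 values shown sits. Compound 2 `O=C(Nc1cccc(-c2ccc(-c3ccccc3)cc2)c1)C(Cl)Cl` gives > 50000 nM in this assay, again only a limit; compound 2 sits at the limit of > 50000 nM in this assay, at which 1 of the 2 values shown sits. With both values being limits, compound 2 cannot be ordered against compound 1 on the numbers shown: neither reaches a measurable inhibitory concentration.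

Compound 3 `O=C(Nc1cccc(-c2ccccc2)c1)C(Cl)Cl` is not yet measured. It differs from compound 2 by hydrogen in place of phenyl on an aromatic carbon, the change sitting para to a large group. Among the measured compounds shown here, no measured step covers a change of this kind, so no direction can be read from the data. Compound 2 is itself at a limit, and nothing shown suggests that losing the phenyl would bring potency into the measurable window, so in this assay no step beyond the scatter is expected, and a further limit is the likely outcome.

For compound 3 the estimate in this assay is 50000 nM, in a range from 20000 nM to 120000 nM. The expected step is a number no higher from compound 2 to compound 3 (the limit leaves the size open).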

Compound 3, half-maximal inhibitory concentration: 46800 nM
For compound 3 the middle estimate is 1.1-fold (0.03 log units) above the measured one; the range from low to high includes it.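

In this assay, among the compounds shown here, compound 3 gives 46800 nM, the only value shown that is a number and not a limit of the assay, so a member of the series without the phenyl at this position, para to a large group, falls within the measurable range. Hydrogen in place of phenyl on this aromatic carbon gives an at least 1.0-fold lower number from compound 2 to compound 3 (0.02 log units; that floor lies within the scatter). The true size of this step stays open, because compound 2 is only a limit of the assay: the limit of > 50000 nM in this assay, at which 1 of the 3 values shown sits.

As far as these compounds go, compound 2 and compound 3 carry only phenyl and hydrogen at this aromatic carbon, so it remains open how a small group such as fluorine, methoxy, an amine or a carboxylic acid would read there. Every compound shown also carries the dichloroacetamide, and what a plain acetamide in its place would give in this assay remains equally open.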